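The compounds below may be only part of what the source reports. "The series", "measured", "known", "first", "only" and "open" are said of these compounds alone.

Measured so far:

compound 1 `NC(=O)N(O)CC1=Cc2cc(OCc3ccccc3)ccc2OC1` gives 380 nM
compound 2 `CCCCCCOc1ccc2c(c1)C=C(CN(O)C(N)=O)CO2` gives 340 nM
compound 3 `NC(=O)N(O)CC1=Cc2cc(Br)ccc2OC1` gives 1400 nM

All three share one core and differ only in the group on one aromatic carbon. In an assay (Cavia porcellus) for inhibition of Polyunsaturated fatty acid 5-lipoxygenase (Homo sapiens) (on this read-out higher numbers stand for weaker inhibition and lower numbers for stronger inhibition), compound 3 stands at the highest number of the three: the step is a 3.7-fold higher number from compound 1 to compound 3 (0.57 log units; beyond the scatter) and, from the other side, a 4.1-fold higher number from compound 2 to compound 3 (0.61 log units; beyond the scatter). Both steps lie beyond the scatter and both say the same thing: trading a large group for bromo weakens inhibition.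

Compound 4 `NC(=O)N(O)CC1=Cc2cc(-c3ccccc3)ccc2OC1` has not yet been measured. The change from compound 3 is phenyl in place of bromo on an aromatic carbon. This runs in the opposite direction to the two measured steps, putting a larger group back where bromo sits, though phenyl is bound directly to the ring rather than through an oxygen as benzyloxy and hexyloxy are. The steps toward compound 3 give reason to expect a lower number for compound 4, of a modest size, in the region of compounds 1 and 2, though the direct attachment leaves room for doubt. The expected step is a 3.1-fold lower number from compound 3 to compound 4 (0.49 log units; beyond the scatter). Compound 4 is therefore estimated at 450 nM, within a range from 150 nM to 1400 nM.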

Compound 4, half-maximal inhibitory concentration: 230 nM
Compound 4: the middle estimate sits 2.0-fold (0.29 log units) above what was measured, and the stated range covers the measured number.
By their numbers in this assay, from the lowest: compounds 4, 2 and 1 (each within the scatter of the next); then compound 3.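

Bound directly to the ring with no oxygen in the link, phenyl still takes this position well clear of bromo in this assay (a 6.1-fold lower number from compound 3 to compound 4 (0.78 log units; beyond the scatter)), so the earlier gain from larger groups does not depend on an oxygen attachment. Phenyl also cannot be told apart from the two oxygen-linked groups, hexyloxy (a 1.5-fold lower number from compound 2 to compound 4 (0.17 log units; within the scatter)) and benzyloxy (a 1.7-fold lower number from compound 1 to compound 4 (0.22 log units; within the scatter)), as both steps lie within the scatter. Among these four compounds, only bromo stands apart, while a flat aromatic ring, a benzyl ether and a straight chain all give numbers within the scatter of one another.

As far as these compounds go, whether an amine, a carboxylic acid or a chain longer than hexyloxy on this aromatic carbon would fit the same picture stays open. Nothing at hand explains why the three larger groups differ from bromo.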